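The source may hold more compounds than are shown below. What is called first, only, known or untested is meant among the compounds shown, and "the series" means these compounds.

Measured so far:
compound 1, `Fc1cccc(O/N=C2/C=C(C#Cc3ccccn3)CCC2)n1`, 9.15 nM
compound 2, `Fc1cccnc1O/N=C1/C=C(C#Cc2ccccn2)CCC1`, 4.01 nM
compound 3, `N#Cc1ccc(F)cc1O/N=C1/C=C(C#Cc2ccccn2)CCC1`, 73.4 nM

These three compounds were tested in an assay on brain (strain Sprague-Dawley) for displacement of a labelled ligand from metabotropic glutamate receptor 5 (Rattus norvegicus), with a stated time of 45 min; a lower number here means a stronger inhibitor, a higher number a weaker inhibitor. Compound 2 gives the lowest number of the three; compound 1 stands nearest, with the step of a 2.3-fold lower number from compound 1 to compound 2 (0.36 log units; beyond the scatter), and compound 3 sits furthest, with a clearly higher number. The unmeasured compound 4, `FCCCOCO/N=C1/C=C(C#Cc2ccccn2)CCC1`, differs from compound 2 in one place: (3-fluoropropoxy)methyl in place of 3-fluoropyridin-2-yl on an oxygen. The one step shown, a 2.3-fold lower number from compound 1 to compound 2 (0.36 log units; beyond the scatter), only swaps one fluoropyridyl for another and so says little about giving up the ring altogether; the higher number for compound 3 hints that this oxygen substituent matters a good deal. For compound 4 a clearly weaker result is therefore expected, roughly a 37-fold higher number from compound 2 to compound 4 (1.57 log units; beyond the scatter), with the estimate 150 nM and a range from 30 nM to 800 nM.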

Compound 4, inhibition constant: 5.42 nM
Compound 4: the middle estimate sits 28-fold (1.44 log units) above what was measured; the whole stated range lies above it.
By their numbers in this assay, from the lowest: compounds 2, 4 and 1 (each within the scatter of the next, the first and the last beyond it); then compound 3.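

In this assay, swapping the ring for the open chain (a 1.4-fold higher number from compound 2 to compound 4 (0.13 log units; within the scatter)) and the comparison with the other fluoropyridine (a 1.7-fold lower number from compound 1 to compound 4 (0.23 log units; within the scatter)) both stay within the scatter. On this oxygen, then, an aromatic ring is not required: (3-fluoropropoxy)methyl, with no ring, matches both 3-fluoropyridin-2-yl and 6-fluoropyridin-2-yl. No available evidence explains this match. Still open, on these data alone, is whether the chain's fluorine matters, and whether a plain propoxymethyl group, a longer chain or a terminal amine would give a similar number.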